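The compounds below may be only part of what the source reports. "The series", "measured", "known", "first", "only" and "open" are said of these compounds alone.

Compound 1 `Cc1ccccc1C[C@H]1COC(=O)[C@@H]1Cc1ccc(Cl)c(Cl)c1` gives 22000 nM
Compound 2 `COc1ccc(C[C@H]2COC(=O)[C@@H]2Cc2ccc(Cl)c(Cl)c2)cc1` gives 37000 nM

In a functional assay on HL-60 cells (Homo sapiens) for cytotoxicity, read by WST assay, with a stated time of 48 h (a higher number here means that more compound is needed for the effect, a lower number that less compound is needed), compound 2 stands at 37000 nM and lies within the scatter of compound 1 (22000 nM). The change to compound 3 (`Cc1ccc(C[C@H]2COC(=O)[C@@H]2Cc2ccc(Cl)c(Cl)c2)cc1C`) is 3,4-dimethylphenyl in place of 4-methoxyphenyl on a saturated chain carbon bound to a saturated ring carbon. Within the data shown here, one measured step bears on it, a change of group at that same place. Among the measured compounds shown here, because a 1.7-fold higher number from compound 1 to compound 2 (0.23 log units; within the scatter) is the only such step, no change beyond the scatter is expected in this assay here. The estimated step is small (a 1.4-fold lower number from compound 2 to compound 3 (0.14 log units; within the scatter)). The expected value for compound 3 is 27000 nM (estimated range 11000 nM to 65000 nM).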

Compound 3, half-maximal effective concentration: 16000 nM
For compound 3 the middle estimate is 1.7-fold (0.23 log units) above the measured one; the range from low to high includes it.
By their numbers in this assay, from the lowest: compounds 3, 1 and 2 (each within the scatter of the next, the first and the last beyond it).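

In this assay, a change at this place, on a saturated chain carbon bound to a saturated ring carbon, now gives a step beyond the scatter: a 2.3-fold lower number from compound 2 to compound 3 (0.36 log units; beyond the scatter), with 3,4-dimethylphenyl, which has no hydrogen-bond acceptor, replacing 4-methoxyphenyl, which has one. The other exchange, a 1.4-fold lower number from compound 1 to compound 3 (0.14 log units; within the scatter), does not separate 3,4-dimethylphenyl from 2-methylphenyl. No measurement here accounts for either step. The compounds shown leave open how an amine or a carboxylic acid on this aromatic ring would read, and the rest of the core stays unchanged throughout.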